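The source may report more compounds than this note shows. Statements on the series, on what has been measured and on what is new or still open speak of the compounds shown alone.

Compound 1 `O=C(Nc1ccc(Br)cc1)N[C@H]1CC[C@H](Oc2ccc(F)cc2)CC1` is known in a functional assay on CRL2813 cells (Homo sapiens) for cytotoxicity, read by sulforhodamine B assay, with a stated time of 5 days (a higher number here means a weaker inhibitor, a lower number a stronger inhibitor), only as a limit, not a number: in this assay compound 1 gives > 20000 nM. Where it stands is told by the limit of > 20000 nM in this assay, at which 1 of the 2 values shown sits. Compound 2 `O=C(Nc1cccc(C(F)(F)F)c1)N[C@H]1CC[C@H](Oc2ccc(OC(F)(F)F)cc2)CC1` in this assay gives 690 nM. Compound 3 `O=C(Nc1ccccc1I)N[C@H]1CC[C@H](Oc2ccc(F)cc2)CC1` differs from compound 1 by 2-iodophenyl in place of 4-bromophenyl on an amide-type nitrogen. For the measured compounds named here, no step between two measured compounds is known, so the size of this change has no precedent here. The step expected is an at least 1.6-fold lower number from compound 1 to compound 3 (0.22 log units; that floor lies within the scatter), toward a stronger inhibitor but modest. Compound 3 is therefore estimated at 12000 nM, with a range from 3000 nM to 40000 nM.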

Compound 3, half-maximal inhibitory concentration: > 20000 nM
Compound 3 ended at the assay's limit; the forecaster's own chance of this, stated with the estimate: 50%; middle value at least 1.6-fold (0.22 log units) away from the limit.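

Compound 1 and compound 3 are both known in this assay only as limits, so no step between them can be read: the limit of > 20000 nM in this assay, at which 2 of the 3 values shown sit.

The compounds shown leave open whether 2-iodophenyl in place of 4-bromophenyl on an amide-type nitrogen changes the inhibition at all.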